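The compounds below may be only part of what the source reports. "The series", "measured", "known", "first", "only" and "open" are said of these compounds alone.

Measured so far in an assay on isolated protein for inhibition of Maltase-glucoamylase (Homo sapiens), tested at 100 uM; on this read-out lower numbers stand for less inhibition and higher numbers for more inhibition at the one concentration tested (going by the name of the read-out):
Compound 1, `CSc1c(C#N)c(N)c(C#N)c(-c2ccccc2)c1-c1ccccc1`, gives 10.5%.
Compound 2, `COc1ccc(-c2c(C#N)c(N)c(C#N)c(SC)c2-c2ccccc2)cc1`, gives 5.7%.
Compound 3, `CSc1c(C#N)c(N)c(C#N)c(Cc2ccccc2)c1-c1ccccc1`, gives "not determined" (no result reported), that is, no reported number.

Compound 1 stands highest of the two numbers shown, yet the single measured step, a number 4.8 percentage points lower from compound 1 to compound 2 (within the scatter), lies within the usual scatter of this kind of measurement, so the two values cannot be told apart. That step consists of a methoxy in place of hydrogen on an aromatic carbon of one of the phenyl groups. Both measured numbers are low on this read-out.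

Compound 4, `CSc1c(C)c(-c2ccccc2)c(C#N)c(N)c1C#N`, differs from compound 1 in one place: methyl in place of phenyl on an aromatic carbon.

Among the compounds with values here, no measured step bears on a change of this kind. Within the data shown here, the only step available concerns a different group at a different position and is itself within the scatter, and compound 3, which also varies at the same carbon of the shared core, carries no number. Nothing in the measured data therefore points to a shift in either direction, and the expected step is a number 1.5 percentage points lower from compound 1 to compound 4 (within the scatter), which means none beyond the scatter. On that basis compound 4 is estimated to give 9% in this assay, with a range from 0% to 22%.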

Compound 4, a percentage reported as inhibition, at one concentration (the size of the read-out at that concentration, not a potency): 6.7%
Estimate against measurement, compound 4: 2.3 percentage points above, and the stated range covers the measured number.
By their numbers in this assay, from the lowest: compounds 2, 4 and 1 (each within the scatter of the next).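

In this assay, within the data shown here, the one measured change at this carbon of the shared core, a phenyl of 6 heavy atoms giving way to a methyl of 1 heavy atom, amounts to a number 3.8 percentage points lower from compound 1 to compound 4 (within the scatter) and so cannot be told apart from no change at all. Even this large a cut in the size of the group, on an aromatic carbon para to an amino group, gives no sign that the phenyl here has any measurable share in the small inhibition seen at the one concentration tested. Nothing available explains this outcome, and no measurement speaks to why the two groups read alike.

As far as these compounds go, whether a group of another kind at this carbon, such as an amine, a carboxylic acid or a longer chain like propyl, would move the number in this assay beyond the scatter stays open. Also open, from the compounds shown here alone, is whether compound 1 and compound 4 would separate at other concentrations, since a reading at a single concentration is not a potency.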